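The source may report more compounds than this note shows. Statements on the series, on what has been measured and on what is new or still open speak of the compounds shown alone.

Compound 3 `CCN(CC)CCn1cnnc1-c1cc(Oc2ccc(NC(=O)Nc3ccccc3C(F)(F)F)cc2F)ccn1` gives the highest of the three numbers in an ADME assay on WI-38 cells (Homo sapiens) for cytotoxicity, read by MTT assay, with a stated time of 72 h (on this read-out lower numbers stand for stronger inhibition and higher numbers for weaker inhibition), at 23500 nM. Compound 1 `CCN(CC)CCn1cnnc1-c1cc(Oc2ccc(NC(=O)Nc3ccc(Cl)c(C(F)(F)F)c3)cc2F)ccn1` gives 6730 nM in this assay, and compound 2 `CCN(CC)CCn1cnnc1-c1cc(Oc2ccc(NC(=O)Nc3cccc(C(F)(F)F)c3)cc2F)ccn1` gives 6920 nM. Compound 4 `CCN(CC)CCn1cnnc1-c1cc(Oc2ccc(NC(=O)Nc3ccc(Cl)cc3Cl)cc2F)ccn1` differs from compound 3 by 2,4-dichlorophenyl in place of 2-(trifluoromethyl)phenyl on an amide-type nitrogen. Among the compounds with values here, no measured step swaps exactly these two groups. The step of a 1.0-fold higher number from compound 1 to compound 2 (0.01 log units; within the scatter) shows that removing a chloro changed little, while a 3.5-fold higher number from compound 1 to compound 3 (0.54 log units; beyond the scatter) and a 3.4-fold higher number from compound 2 to compound 3 (0.53 log units; beyond the scatter) show that the move to 2-(trifluoromethyl)phenyl brought a modest rise. Compound 4 carries a different halogenated group on the same nitrogen, so a small step down in this assay is expected, a 1.7-fold lower number from compound 3 to compound 4 (0.22 log units; within the scatter). Compound 4 is estimated at 14000 nM, within a range of 5000 nM to 40000 nM.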

Compound 4, half-maximal inhibitory concentration: 4280 nM
Compound 4: the middle estimate sits 3.3-fold (0.51 log units) above what was measured, outside the stated range (below it).
By their numbers in this assay, from the lowest: compounds 4, 1 and 2 (each within the scatter of the next); then compound 3.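

In this assay, 2,4-dichlorophenyl in place of 2-(trifluoromethyl)phenyl gives a 5.5-fold lower number from compound 3 to compound 4 (0.74 log units; beyond the scatter), so the rise seen with 2-(trifluoromethyl)phenyl does not extend to every halogenated phenyl on this nitrogen. The other two steps, a 1.6-fold lower number from compound 2 to compound 4 (0.21 log units; within the scatter) and a 1.6-fold lower number from compound 1 to compound 4 (0.20 log units; within the scatter), lie within the scatter, which leaves compound 3 alone apart from the other three. No measurement here explains why these groups differ. Still open, on these data alone, is whether a plain phenyl, or a phenyl carrying a methoxy group, an amine or a carboxylic acid, would stay with those three or move towards compound 3.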